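This account rests on a few compounds, and the source may have more. Where it says the series, first, only, none or still open, it means among the compounds named here.

Series notes. The shared core of compound 1 `O=C(Nc1ccccc1)Nc1nnc(Sc2ncnc3scc(-c4ccncc4)c23)s1` carries a phenylurea; in a functional assay on PC-3 cells (Homo sapiens) for antiproliferative activity, read by MTT assay, with a stated time of 48 h (a lower number here means a stronger inhibitor, a higher number a weaker inhibitor), compound 1 gives 5700 nM. Compound 2 `O=C(Nc1cccc(C(F)(F)F)c1)Nc1nnc(Sc2ncnc3scc(-c4ccncc4)c23)s1` gives 11500 nM in this assay, and compound 3 `COc1ccc(NC(=O)Nc2nnc(Sc3ncnc4scc(-c5ccncc5)c34)s2)cc1` gives 9900 nM. Among the three numbers compound 3 stands second highest, with compound 2 nearest and compound 1 furthest; both gaps are within the scatter, so no ordering can be read from them. The steps to substituted phenyl groups were a 2.0-fold higher number from compound 1 to compound 2 (0.30 log units; within the scatter) and a 1.7-fold higher number from compound 1 to compound 3 (0.24 log units; within the scatter), and between the two substituted analogues a 1.2-fold lower number from compound 2 to compound 3 (0.07 log units; within the scatter).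

Compound 4 `Cc1ccc(NC(=O)Nc2nnc(Sc3ncnc4scc(-c5ccncc5)c34)s2)cc1` differs from compound 3 by methyl in place of methoxy on an aromatic carbon, on an aromatic carbon of a six-membered aromatic ring of carbon only. Among the compounds with values here, no measured step covers a methoxy to methyl exchange; the steps that bear on it are those that vary this ring, and none of them left the scatter. A step beyond the scatter is therefore not expected in this assay, in either direction. The estimated step is a 1.2-fold lower number from compound 3 to compound 4 (0.07 log units; within the scatter), giving for compound 4 an expected value of 8500 nM with a range from 4000 nM to 18000 nM.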

Compound 4, half-maximal inhibitory concentration: 2100 nM
Estimate against measurement, compound 4: 4.0-fold (0.61 log units) above; the whole stated range lies above it.
By their numbers in this assay, from the lowest: compound 4; then compounds 1, 3 and 2 (each within the scatter of the next).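

In this assay, within the data shown here, the substituent on the aromatic carbon para to a large group now matters: methyl in place of methoxy gives a step beyond the scatter (a 4.7-fold lower number from compound 3 to compound 4 (0.67 log units; beyond the scatter)), the first such step among the compounds varying this ring. Methyl also separates from hydrogen at this position (a 2.7-fold lower number from compound 1 to compound 4 (0.43 log units; beyond the scatter)), while methoxy in the same place does not (a 1.7-fold higher number from compound 1 to compound 3 (0.24 log units; within the scatter)), so the two groups are not interchangeable here. The change from 3-(trifluoromethyl)phenyl to 4-methylphenyl also leaves the scatter (a 5.5-fold lower number from compound 2 to compound 4 (0.74 log units; beyond the scatter)), but it alters both the group and its place on the ring.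

Nothing available explains why methyl and methoxy differ at this position. Open, from the compounds shown here alone, is whether ethyl, chlorine or a longer chain at this position would follow methyl or fall back towards hydrogen and methoxy, and whether methyl keeps its step at another carbon of the ring.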